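The source may hold more compounds than are shown below. What is called first, only, known or untested is meant among the compounds shown, and "the series" means these compounds.

Three measured compounds and one unmeasured compound share a saturated chain carbon bound to two aromatic carbons, with a third aromatic ring attached at that carbon. Compound 1 `Cc1ccc(C(c2c[nH]c3ccccc23)c2c[nH]c3ccccc23)cc1` carries a 4-methylphenyl there. In an ADME assay on WS1 cells (Homo sapiens) for cytotoxicity, read by MTT assay, with a stated time of 48 h (on this read-out higher numbers stand for weaker inhibition and lower numbers for stronger inhibition), compound 1 gives 58400000 nM. Compound 2 `Fc1cc(F)cc(C(c2c[nH]c3ccccc23)c2c[nH]c3ccccc23)c1` differs from compound 1 in one place: 3,5-difluorophenyl in place of 4-methylphenyl on a saturated chain carbon bound to two aromatic carbons. This change made a 1.6-fold lower number from compound 1 to compound 2 (0.21 log units; within the scatter), so in this assay compound 2 gives 36000000 nM.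

Compound 3 `Cc1ccc(C(c2c[nH]c3ccc(I)cc23)c2c[nH]c3ccc(I)cc23)cc1` keeps the 4-methylphenyl of compound 1 but has a different core; how the core of compound 3 differs from the core of compound 1 is not broken down here. In this assay compound 3 gives 16200000 nM, the lowest of the three measured numbers, and its gaps to compound 2 and to compound 1 lie beyond the scatter.

Compound 4 `Fc1cc(F)cc(C(c2c[nH]c3ccc(I)cc23)c2c[nH]c3ccc(I)cc23)c1` is the not yet measured partner of compound 3, made by the same change that turned compound 1 into compound 2: 3,5-difluorophenyl in place of 4-methylphenyl on a saturated chain carbon bound to two aromatic carbons. Among the measured compounds shown here, because the earlier step was a 1.6-fold lower number from compound 1 to compound 2 (0.21 log units; within the scatter), a step of similar size is expected here, namely a 1.6-fold lower number from compound 3 to compound 4 (0.21 log units; within the scatter), which rests on the single pair of compound 1 and compound 2. On that basis compound 4 is expected to give about 10000000 nM in this assay. A range from 5000000 nM to 25000000 nM is estimated for compound 4, since a single earlier pair gives only weak guidance.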

Compound 4, half-maximal inhibitory concentration: 28500000 nM
Compound 4: the middle estimate sits 2.9-fold (0.45 log units) below what was measured, and the stated range ends below it.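

In this assay the swap to 3,5-difluorophenyl gave a 1.8-fold higher number from compound 3 to compound 4 (0.25 log units; within the scatter) and so did not repeat the direction seen on the core of compound 1. Set side by side, the two steps do not match, and the gap between them is wider than the usual scatter of two such steps allows: the same change on two cores in this assay, a 1.6-fold lower number (0.21 log units; within the scatter) from compound 1 to compound 2 and a 1.8-fold higher number (0.25 log units; within the scatter) from compound 3 to compound 4, 2.9-fold (0.46 log units) apart, beyond the scatter of two such steps. Among the compounds shown here, this shows that, in this small set, the step seen on one core did not carry over to the other in direction, but it rests on only two pairs, each step taken alone lies within the scatter, and it does not show why the two cores differ or what the same change would do on any further core.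

The compounds shown carry only 4-methylphenyl and 3,5-difluorophenyl on the saturated chain carbon bound to two aromatic carbons, and they cover only two cores. Going by these compounds, it remains open whether an amine, a carboxylic acid or a longer chain at that carbon would give steps that hold from one core to the other, and how a matching pair on a third core would fall.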